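Swapping 4-Fluorophenyl for 3-(Methylsulfanyl)phenyl on Compound 2

This account rests on a few compounds, and the source may have more. Where it says the series, first, only, none or still open, it means among the compounds named here.

Within the data shown here, in an ADME assay on WI-38 cells (Homo sapiens) for cytotoxicity, read by MTT assay, with a stated time of 72 h (a higher number here means a weaker inhibitor, a lower number a stronger inhibitor), compound 1 `O=C(CCc1cccc2c1B(O)OC2)Nc1cccc(Br)c1` gives 20000 nM, while compound 2 `O=C(CCc1cccc2c1B(O)OC2)Nc1cccc(-c2ccc(F)cc2)c1` gives 4100 nM, the lower of the two numbers measured so far. Among the measured compounds shown here, the only measured step, a 4.9-fold lower number from compound 1 to compound 2 (0.69 log units; beyond the scatter), puts 4-fluorophenyl in place of bromo on an aromatic carbon. Compound 3 `CSc1cccc(-c2cccc(NC(=O)CCc3cccc4c3B(O)OC4)c2)c1` keeps the shared core and carries 3-(methylsulfanyl)phenyl in place of 4-fluorophenyl on an aromatic carbon, meta to a large group: 3-(methylsulfanyl)phenyl in place of 4-fluorophenyl on an aromatic carbon. The measured step exchanged bromo for a substituted phenyl group, whereas this change exchanges one substituted phenyl group for another, so it offers only limited guidance. For the measured compounds named here, no measured step shows a change of this kind. In this assay, no change beyond the scatter is expected, and no firm direction can be given. The estimated step is a 1.1-fold lower number from compound 2 to compound 3 (0.06 log units; within the scatter). Compound 3 is expected at 3600 nM, with an estimated range from 1500 nM to 9000 nM.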

Compound 3, half-maximal inhibitory concentration: 2000 nM
The estimate for compound 3 lay 1.8-fold (0.26 log units) above the measured number; the range from low to high includes it.
By their numbers in this assay, from the lowest: compound 3; then compound 2; then compound 1.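

In this assay, among these compounds, this position, so far seen only in the exchange of bromo for a substituted phenyl group, also distinguishes between two substituted phenyl groups: 3-(methylsulfanyl)phenyl in place of 4-fluorophenyl gives a 2.1-fold lower number from compound 2 to compound 3 (0.31 log units; beyond the scatter) as a small step that still lies just beyond the scatter. Against bromo, the same group gives a 10-fold lower number from compound 1 to compound 3 (1.00 log units; beyond the scatter) as the largest step among these compounds, and compound 3 now has the lowest number of the three. No measurement at hand explains the difference between the two phenyl groups.

These two groups differ both in their substituent and in where it stands on the phenyl ring, and the compounds shown do not separate the two. Going by these compounds, whether 3-fluorophenyl, 4-(methylsulfanyl)phenyl, or a phenyl group carrying an amine or a carboxylic acid would shift the number further remains open.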